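Aryl to propyl on the exocyclic alkene of the oxindole series

The source may report more compounds than this note shows. Statements on the series, on what has been measured and on what is new or still open speak of the compounds shown alone.

Among the measured compounds shown here, in a functional assay on DU-145 cells (Homo sapiens) for cytotoxicity, read by sulforhodamine B assay, with a stated time of 48 h (on this read-out lower numbers stand for stronger inhibition and higher numbers for weaker inhibition), compound 1 `COc1ccc(/C=C2\C(=O)N(Cc3cn([C@@H]4O[C@H](COC(C)=O)[C@@H](OC(C)=O)[C@H](OC(C)=O)[C@H]4OC(C)=O)nn3)c3ccccc32)cc1OC` gives 24900 nM, the higher of the two numbers so far; compound 2 `CC(=O)OC[C@H]1O[C@@H](n2cc(CN3C(=O)/C(=C/c4cccs4)c4ccccc43)nn2)[C@H](OC(C)=O)[C@@H](OC(C)=O)[C@@H]1OC(C)=O` gives 23400 nM in this assay, and the two lie within the scatter of each other. Compound 3 `CCC/C=C1\C(=O)N(Cc2cn([C@@H]3O[C@H](COC(C)=O)[C@@H](OC(C)=O)[C@H](OC(C)=O)[C@H]3OC(C)=O)nn2)c2ccccc21` differs from compound 1 by propyl in place of 3,4-dimethoxyphenyl on a double-bonded chain carbon bound to a double-bonded ring carbon. For the measured compounds named here, no measured pair shows this kind of exchange, so the step is expected to be at most modest, toward weaker inhibition or within the scatter. Compound 3 is therefore estimated at 40000 nM in this assay, range 15000 nM to 100000 nM, a step of a 1.6-fold higher number from compound 1 to compound 3 (0.21 log units; within the scatter).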

Compound 3, half-maximal inhibitory concentration: 26600 nM
For compound 3 the middle estimate is 1.5-fold (0.18 log units) above the measured one, within the range that was stated.
By their numbers in this assay, from the lowest: compounds 2, 1 and 3 (each within the scatter of the next).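

In this assay, propyl in place of 3,4-dimethoxyphenyl on a double-bonded chain carbon bound to a double-bonded ring carbon gives a 1.1-fold higher number from compound 1 to compound 3 (0.03 log units; within the scatter). This position therefore tolerates the exchange of an aromatic ring of carbon only, with its two hydrogen-bond acceptors, for a small open chain without a change beyond the scatter. Nothing available explains this result.

Still open, from the compounds shown here alone, is whether any group at this position moves the number beyond the scatter, for instance a primary amine, a carboxylic acid or a longer alkyl chain such as octyl. The compounds shown also leave open whether a stronger number is attainable here at all.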